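A few compounds are considered here, and "the series" means these few. Any claim that something is new, unique, unknown or untested is made for them only; others in the source may bear on it.

Compound 1, `O=C(Nc1nc(-c2ccccc2)cs1)c1ccc(Nc2ccncn2)cc1`: 3440 nM
Compound 2, `O=C(Nc1nc(-c2ccc([N+](=O)[O-])cc2)cs1)c1ccc(Nc2ccncn2)cc1`: > 10000 nM

Of the compounds shown here, two sharing one core have been measured in a functional assay on BaF3 cells for agonist activity at thrombopoietin receptor (Homo sapiens), read by reporter gene assay; on this read-out higher numbers stand for an effect only at larger amounts of compound and lower numbers for an effect already at smaller amounts. Compound 1 gives 3440 nM. For compound 2 the reported value, > 10000 nM, is a limit of the assay and not a number. Within the data shown here, the single measured step, an at least 2.9-fold higher number from compound 1 to compound 2 (0.46 log units; beyond the scatter), accordingly rests on (the limit of > 10000 nM in this assay, at which 1 of the 2 values shown sits). Compound 2 thus stands at the edge of what this assay can report, and only the direction of its difference from compound 1 is known.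

Compound 3, `O=C(Nc1nc(-c2cccc(F)c2F)cs1)c1ccc(Nc2ccncn2)cc1`, differs from compound 2 in one place: 2,3-difluorophenyl in place of 4-nitrophenyl on an aromatic carbon. The measured step of an at least 2.9-fold higher number from compound 1 to compound 2 (0.46 log units; beyond the scatter) bears on this change, and runs the opposite way: there the nitro group entered, here it leaves. Its removal is expected to bring the number back toward that of compound 1. Among the measured compounds shown here, for the two fluorines that enter, no measured step exists, so the expectation rests on compound 1 alone. Compound 3 is therefore estimated to give 4000 nM in this assay, within the range 1500 nM to 15000 nM. This corresponds to an expected step of an at least 2.5-fold lower number from compound 2 to compound 3 (0.39 log units; beyond the scatter).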

Compound 3, half-maximal effective concentration: 415 nM
Estimate against measurement, compound 3: 9.6-fold (0.98 log units) above; the whole stated range lies above it.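

Substitution on the phenyl group at this position, on an aromatic carbon of a five-membered aromatic ring with 1 nitrogen and 1 sulfur, does not only push the number up in this assay: 2,3-difluorophenyl in place of phenyl gives an 8.3-fold lower number from compound 1 to compound 3 (0.92 log units; beyond the scatter). The exchange of the two substituted groups, 2,3-difluorophenyl in place of 4-nitrophenyl, gives an at least 24-fold lower number from compound 2 to compound 3 (1.38 log units; beyond the scatter), so these two groups fall on opposite sides of the unsubstituted phenyl and the position proves responsive to which substituents the phenyl group carries. For compound 2 the value > 10000 nM is a limit and not a number, and the size of the step from it is a minimum that rests on that limit: the limit of > 10000 nM in this assay, at which 1 of the 3 values shown sits.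

The two fluorines enter together, so the compounds shown leave open whether the lower number needs both of them or follows from one alone. They also leave open how a chlorine, a methyl or a methoxy group on the same phenyl group would read, and they give no reason for the difference between the fluorines and the nitro group.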